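The source may hold more compounds than are shown below. What is called first, only, known or untested is meant among the compounds shown, and "the series" means these compounds.

In a functional assay on BGC-823 cells (Homo sapiens) for antiproliferative activity, read by MTT assay, tested at 5 uM (on this read-out lower numbers stand for a weaker effect and higher numbers for a stronger effect at the one concentration tested), compound 1 `COc1cc(C2=NN(C(C)=O)C(c3cccc(F)c3)O2)cc(OC)c1OC` gives 37.7%. Compound 2 `COc1cc(C(=O)N/N=C/c2ccccc2F)cc(OC)c1OC` gives 76.5% in this assay. Compound 3 `COc1cc(C(=O)N/N=C/c2ccc(Cl)c([N+](=O)[O-])c2)cc(OC)c1OC` gives 2.3% in this assay, the lowest of the three numbers: compound 1 stands above it by a margin beyond the scatter, and compound 2 lies furthest away, also beyond the scatter. Compound 4 `COc1cc(C(=O)N/N=C/c2ccc(Cl)c(Cl)c2)cc(OC)c1OC` is not yet measured. It differs from compound 3 in one place: chloro in place of nitro on an aromatic carbon. For the measured compounds named here, no measured pair shows this change, so the direction rests on expectation alone. Because compound 3 gives 2.3%, there is little room for a lower number. The step is expected to be upward, modest, and beyond the scatter: a number 17.7 percentage points higher from compound 3 to compound 4 (beyond the scatter). Compound 4 is estimated to give 20%, within 0% to 55%.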

Compound 4, a percentage reported as inhibition, at one concentration (the size of the read-out at that concentration, not a potency): 32.7%
Estimate against measurement, compound 4: 12.7 percentage points below, within the range that was stated.
By their numbers in this assay, from the lowest: compound 3; then compounds 4 and 1 (each within the scatter of the next); then compound 2.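

In this assay, for the compounds shown here, chloro in place of nitro on an aromatic carbon, ortho to a chloro group, gives a number 30.4 percentage points higher from compound 3 to compound 4 (beyond the scatter), the first sign that the group at this position can shift the read-out. A larger change, 3,4-dichlorophenyl in place of 2-fluorophenyl on a carbon with a double bond to nitrogen, gives a number 43.8 percentage points lower from compound 2 to compound 4 (beyond the scatter), so this dichloro pattern does not match the 2-fluorophenyl compound. Nothing available explains either step. The compounds shown leave open how an amine or a carboxylic acid at this position would read.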